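The compounds below may be only part of what the source reports. "The series", "measured", "known", "first", "only" and "open" are said of these compounds alone.

The compounds here share one core and differ in a single group on an aromatic carbon. In an ADME assay on Vero cells (Chlorocebus sabaeus) for cytotoxicity, read by MTT assay, with a stated time of 72 h (a higher number here means that more compound is tolerated, a lower number that less compound is tolerated), compound 1 (`CC1(C)C=Cc2c(ccc(C(=O)/C=C/c3ccc(F)cc3)c2O)O1`) gives 158000 nM and compound 3 (`CC1(C)C=Cc2c(ccc(C(=O)/C=C/c3ccc(C#N)cc3)c2O)O1`) gives 80200 nM. Compound 2 (`CC1(C)C=Cc2c(ccc(C(=O)/C=C/c3ccc(Br)cc3)c2O)O1`) gives "not determined" (no result reported), so it adds no number to compare. Among the measured compounds shown here, compound 3 therefore stands level with compound 1, the only other compound with a number, since the two values lie within the scatter of each other.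

The next compound, compound 4 (`CC1(C)C=Cc2c(ccc(C(=O)/C=C/c3ccc([N+](=O)[O-])cc3)c2O)O1`), carries nitro in place of cyano on an aromatic carbon, para to a large group: nitro in place of cyano on an aromatic carbon. For the measured compounds named here, no compound with a nitro group has been measured yet, so only one measured step bears on this change. That step is a 2.0-fold lower number from compound 1 to compound 3 (0.29 log units; within the scatter), and it also swaps one group for another on an aromatic carbon. Because that single step is a 2.0-fold lower number from compound 1 to compound 3 (0.29 log units; within the scatter), no step beyond the scatter is expected in this assay, and no direction can be argued with confidence. The expected change is a 1.1-fold lower number from compound 3 to compound 4 (0.03 log units; within the scatter). One step is thin evidence, so the expected range is kept wide. For compound 4 the estimated value is 75000 nM, with an expected range from 30000 nM to 170000 nM.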

Compound 4, half-maximal cytotoxic concentration: 106000 nM
Beside the measured number, compound 4's estimate is 1.4-fold (0.15 log units) below it, and the stated range covers the measured number.
By their numbers in this assay, from the lowest: compounds 3, 4 and 1 (each within the scatter of the next).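

In this assay nitro on this aromatic carbon, para to a large group, gives a 1.3-fold higher number from compound 3 to compound 4 (0.12 log units; within the scatter) against cyano and a 1.5-fold lower number from compound 1 to compound 4 (0.17 log units; within the scatter) against fluoro, so both new steps stay within the scatter. Among the compounds shown here, until now a single step between two groups was all that bore on this position; with compounds 1, 3 and 4 there are three groups at the same place, and no pair among them can be told apart in this assay, even though cyano and nitro differ in their heavy atoms and in their hydrogen-bond acceptors. Nothing measured here gives a reason for this lack of separation.

The pattern rests on only these three numbers, and the bromo of compound 2 has no result to test it. As far as these compounds go, what an amine, a carboxylic acid or a longer alkyl chain would give on this same aromatic carbon stays open, as does whether a change anywhere else on the shared core would move the number beyond the scatter.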